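The source may report more compounds than this note shows. Statements on the series, on what has been measured and on what is new or still open speak of the compounds shown alone.

Measured compounds: compound 1 `FC(F)(F)c1ccccc1-c1nc(NCc2ccccc2)c2ccccc2n1` gives 3100 nM in an assay on a protein complex for inhibition of ubiquitin carboxyl-terminal hydrolase 1/WD repeat-containing protein 48 (Homo sapiens), read by fluorescence; on this read-out higher numbers stand for weaker inhibition and lower numbers for stronger inhibition; compound 2 `FC(F)(F)c1ccc(CNc2nc(-c3ccccc3C(F)(F)F)nc3ccccc23)cc1` gives 8900 nM in this assay.

Compound 2 stands highest of the two numbers, with compound 1 nearest by a 2.9-fold higher number from compound 1 to compound 2 (0.46 log units; beyond the scatter). Compound 3 `FC(F)(F)c1ccccc1-c1nc(NCc2ccc(-c3ccccc3)cc2)c2ccccc2n1` differs from compound 2 by phenyl in place of trifluoromethyl on an aromatic carbon. For the measured compounds named here, no measured step swaps one group for another at this place; the only step that bears on it, from compound 1 to compound 2, added trifluoromethyl there and gave a modest shift. For compound 3 this leaves the direction open, so no step beyond the scatter is expected: a 1.0-fold higher number from compound 2 to compound 3 (0.00 log units; within the scatter). Compound 3 is therefore estimated at 9000 nM, with a range from 3000 nM to 27000 nM.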

Compound 3, half-maximal inhibitory concentration: 3700 nM
Compound 3: middle estimate off by 2.4-fold (0.39 log units), on the high side; the range from low to high includes it.
By their numbers in this assay, from the lowest: compounds 1 and 3 (each within the scatter of the next); then compound 2.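

In this assay, phenyl on an aromatic carbon para to a large group gives a 2.4-fold lower number from compound 2 to compound 3 (0.38 log units; beyond the scatter) when set against trifluoromethyl at the same place. Against hydrogen at this place, phenyl gives a 1.2-fold higher number from compound 1 to compound 3 (0.08 log units; within the scatter) in the same assay, so the rise seen with trifluoromethyl does not recur with phenyl, although phenyl brings more heavy atoms. Nothing available explains why these two groups differ here.

The compounds shown leave open whether any group at this place gives a number lower than compound 1 does. An amine, a carboxylic acid or a methoxy group could test that, and a longer chain could show how far out from the ring the place accepts substitution.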